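A few compounds are considered here, and "the series" means these few. Any claim that something is new, unique, unknown or untested is made for them only; others in the source may bear on it.

Measured so far in an assay for binding affinity to Neuropeptide Y receptor type 1 (Homo sapiens), read by radioligand binding; on this read-out lower numbers stand for stronger inhibition and higher numbers for weaker inhibition:
compound 1 `CS(=O)(=O)c1cc(N)c2ncccc2c1[N+](=O)[O-]` — > 10000 nM
compound 2 `COc1ccc(S(=O)(=O)c2cc(N)c3ncccc3c2[N+](=O)[O-])cc1` — 1140 nM

Compound 1 sits at a limit of this assay, > 10000 nM, not a number (the limit of > 10000 nM in this assay, at which 1 of the 2 values shown sits). Compound 2 holds the only number shown, 1140 nM; the step of an at least 8.7-fold lower number from compound 1 to compound 2 (0.94 log units; beyond the scatter) is therefore a lower bound only.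

Compound 3 `Nc1cc(S(=O)(=O)c2cccc(Cl)c2)c([N+](=O)[O-])c2cccnc12` carries 3-chlorophenyl in place of 4-methoxyphenyl on a sulfonyl sulfur. Going by the values given here, no measured step bears directly on an aryl-to-aryl swap at the sulfonyl sulfur; the sole step, an at least 8.7-fold lower number from compound 1 to compound 2 (0.94 log units; beyond the scatter), concerns methyl against aryl and does not transfer. The expectation for compound 3 in this assay is thus no step beyond the scatter, a 1.0-fold lower number from compound 2 to compound 3 (0.02 log units; within the scatter), giving an estimated 1100 nM with a range of 300 nM to 4500 nM.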

Compound 3, inhibition constant: 892 nM
Estimate against measurement, compound 3: 1.2-fold (0.09 log units) above; the range from low to high includes it.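

The swap from 4-methoxyphenyl to 3-chlorophenyl on the sulfonyl sulfur stays within the scatter (a 1.3-fold lower number from compound 2 to compound 3 (0.11 log units; within the scatter)), so two different aryl groups read alike at this position. A second aryl compound also separates from the methyl compound (an at least 11-fold lower number from compound 1 to compound 3 (1.04 log units; beyond the scatter)), so the gap over methyl now rests on two aryl groups rather than one. Compound 1 stands at a limit, not a number, so that step is a lower bound only.

Open, going by these compounds, is whether a non-aromatic group such as cyclohexyl or a longer alkyl chain on the sulfonyl sulfur reads like the aryl groups or like methyl. Also open, on these data alone, is how an amine or a carboxylic acid on the phenyl ring would read.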